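The source may hold more compounds than are shown below. What is called first, only, known or untested is meant among the compounds shown, and "the series" means these compounds.

Measured compounds:
- compound 1 `Cc1ccc(NS(=O)(=O)c2ccc(N3CCNC3=O)cc2)cc1C`: 230 nM
- compound 2 `O=C1NCCN1c1ccc(S(=O)(=O)Nc2ccc3c(c2)CCC3)cc1`: 190 nM
- compound 3 `CC(C)(C)c1cc(NS(=O)(=O)c2ccc(N3CCNC3=O)cc2)cc(C(C)(C)C)c1`: limit only, see below

In a functional assay on HT-29 cells (Homo sapiens) for antiproliferative activity, read by sulforhodamine B assay, with a stated time of 48 h (on this read-out higher numbers stand for weaker inhibition and lower numbers for stronger inhibition), compound 1 gives 230 nM and compound 2 gives 190 nM; these two sit within the usual scatter of each other, so no order between them can be read. Compound 1 therefore holds the higher of the two numbers available, with nothing beyond the scatter separating it from compound 2. Compound 3 is reported only as a limit in this assay, > 1000 nM. That entry is the limit of > 1000 nM in this assay, at which 1 of the 3 values shown sits, so it supplies no number for comparison.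

Compound 4 `Cc1ccc(NS(=O)(=O)c2ccc(N3CCNC3=O)cc2)c(C)c1` is not yet measured. Against compound 1 the change is 2,4-dimethylphenyl in place of 3,4-dimethylphenyl on a sulfonamide nitrogen. Among the compounds with values here, no measured pair in the set isolates such a move of a methyl group, so the expectation rests on compound 1 alone. The step from compound 1 to compound 4 in this assay is expected to be small, and if anything toward a higher number, estimated as a 1.7-fold higher number from compound 1 to compound 4 (0.24 log units; within the scatter). Compound 4 is thus estimated at 400 nM, with a range from 150 nM to 1500 nM.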

Compound 4, half-maximal inhibitory concentration: 180 nM
Estimate against measurement, compound 4: 2.2-fold (0.35 log units) above; low and high end bracket the measured number.
By their numbers in this assay, from the lowest: compounds 4, 2 and 1 (each within the scatter of the next). At a limit, above all of these: compound 3.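

In this assay, 2,4-dimethylphenyl in place of 3,4-dimethylphenyl on a sulfonamide nitrogen gives a 1.3-fold lower number from compound 1 to compound 4 (0.11 log units; within the scatter) and so no order can be read between the two isomers. Within the data shown here, this is the only step that isolates one change at this position, and it shows that this move of a methyl group leaves the number within the scatter, which the earlier compounds could not show. Nothing available explains this outcome.

Compound 3 remains a limit and not a number: > 1000 nM in this read-out. From the compounds shown here alone, whether a single methyl, a methoxy group, a chlorine or a carboxylic acid on the phenyl ring would keep the number in the range of compound 4 stays open, as does the effect of any change to the rest of the shared core.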